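A few compounds are considered here, and "the series" means these few. Any claim that something is new, unique, unknown or untested is made for them only; others in the source may bear on it.

The set centres on compound 1 `CCc1ccc(-c2nc(N)c3cc(Cc4ccccc4)sc3n2)o1`. Within the data shown here, in a functional assay on CHO-K1 cells for antagonist activity at adenosine receptor A1 (Homo sapiens), read by a beta-galactosidase reporter and cAMP accumulation, with stated times of 15 min and 6 h (a higher number here means a weaker inhibitor, a lower number a stronger inhibitor), compound 1 gives 223 nM, the only plain number among the three measured compounds. Compound 2 `C=C(c1ccccc1)c1cc2c(N)nc(-c3nc(C)cs3)nc2s1` stops at a limit in this assay, > 594 nM. Compound 3 `Nc1nc(-c2cccc(C(F)(F)F)c2)nc2sc(Cc3ccccc3)cc12` likewise stops at a limit in this assay, > 1000 nM. Among the measured compounds shown here, those two results, the limit of > 1000 nM in this assay, at which 1 of the 3 values shown sits, and (the limit of > 594 nM in this assay, at which 1 of the 3 values shown sits), are limits of the assay and not measured values, so no measured step between compounds can be built from them, and compound 1 stands alone as the one figure on record.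

Compound 4 `Nc1nc(-c2cnccn2)nc2sc(Cc3ccccc3)cc12` has not yet been tested in this assay. It differs from compound 1 in a single place: pyrazin-2-yl in place of 5-ethylfuran-2-yl on an aromatic carbon. For the measured compounds named here, with no measured step of this kind to lean on, the size of the change is a matter of estimate only. Compound 3, which also carries a six-membered aromatic ring, ends at its limit of > 1000 nM in this assay. On that basis compound 4 is expected to be weaker than compound 1, with a step of a 2.7-fold higher number from compound 1 to compound 4 (0.43 log units; beyond the scatter) that goes beyond the usual scatter. Compound 4 is accordingly estimated at 600 nM, in a range from 150 nM to 2500 nM.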

Compound 4, inhibition constant: 91 nM
The estimate for compound 4 lay 6.6-fold (0.82 log units) above the measured number; measured number below the stated range.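

Replacing 5-ethylfuran-2-yl with pyrazin-2-yl on the aromatic carbon between two ring nitrogen atoms gives a 2.5-fold lower number from compound 1 to compound 4 (0.39 log units; beyond the scatter) in this assay, so this place in the shared core accepts a six-membered aromatic ring with 2 hetero atoms and still gives a lower number than the five-membered ring of the starting compound. The earlier compounds shown here could not show this, as the only six-membered aromatic ring among them, in compound 3, gave no number to compare. In this assay compound 3 stops at a limit and not a measured value: the limit of > 1000 nM in this assay, at which 1 of the 4 values shown sits.

Steps to or from the compounds that stop at a limit cannot be read, so this single step from the furan to the pyrazine is all that describes the position, and it changes ring size, ring nitrogen atoms and the ethyl chain at once. The compounds shown leave open which of these changes carries the step, a question that furan-2-yl without its ethyl chain or pyridin-2-yl at the same carbon would begin to separate.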